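Two Pairs, One Phenyl Removed from an Aromatic Carbon

The compounds below may be only part of what the source reports. "The series", "measured", "known", "first", "only" and "open" are said of these compounds alone.

Measured so far:
compound 1, `N=C(S)CCn1nc(-c2ccccc2)ccc1=S`, 73.4 mg/kg
compound 2, `N=C(S)CCn1ncccc1=S`, 100 mg/kg
compound 3, `N=C(S)CCn1nc(-c2ccccc2)c2ccccc2c1=O`, 66.5 mg/kg

In a functional assay on the whole organism (stomach) with Rattus norvegicus as the target (a higher number here means that more compound is needed for the effect, a lower number that less compound is needed), these three compounds give numbers that all lie within the usual scatter of one another, so no order among them can be read from the data. The step from compound 1 to compound 2 is hydrogen in place of phenyl on an aromatic carbon, and it gives a 1.4-fold higher number from compound 1 to compound 2 (0.13 log units; within the scatter). Compound 4, `N=C(S)CCn1ncc2ccccc2c1=O`, has not been measured in this assay. It relates to compound 3 as compound 2 relates to compound 1: the change is hydrogen in place of phenyl on an aromatic carbon. The surroundings are not identical, since in compound 3 the ring carrying the phenyl is part of a fused or bridged system of two rings, and the place is ortho to a fused ring and meta to a fused ring; so this is the same kind of change, not the same one. The difference between the two cores is not broken down here.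

The expected step from compound 3 to compound 4 is a 1.4-fold higher number from compound 3 to compound 4 (0.13 log units; within the scatter), resting on the earlier pair, because a 1.4-fold higher number from compound 1 to compound 2 (0.13 log units; within the scatter) was small. Compound 4 is therefore estimated at 90 mg/kg, within 50 mg/kg to 170 mg/kg.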

Compound 4, dose for half-maximal effect: 90.1 mg/kg
Compound 4: middle estimate off by 1.0-fold (0.00 log units), on the low side; measured number inside the range.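

In this assay, putting hydrogen in place of phenyl on this fused core gives a 1.4-fold higher number from compound 3 to compound 4 (0.13 log units; within the scatter). Set beside the same change on the other core, the two steps cannot be told apart: the same change on two cores in this assay, a 1.4-fold higher number (0.13 log units; within the scatter) from compound 1 to compound 2 and a 1.4-fold higher number (0.13 log units; within the scatter) from compound 3 to compound 4, 1.0-fold (0.00 log units) apart, within the scatter of two such steps So far, this swap can be carried from one core to the other without a detectable difference, but this rests on only two pairs, and both steps are small enough to be lost in the ordinary spread of repeated measurements, so neither pair shows that removing the phenyl truly changes the dose needed.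

The compounds shown carry only phenyl or hydrogen at this aromatic carbon, so it remains open whether another group there, such as an amine or a carboxylic acid, would move the number beyond the scatter. All four compounds also share the same side chain on the ring nitrogen, which leaves open what a longer chain at that point would do.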